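A few compounds are considered here, and "the series" means these few. Any claim that something is new, unique, unknown or untested is made for them only; others in the source may bear on it.

Measured so far in a physicochemical assay for lipophilicity, read by HPLC; on this read-out higher numbers stand for higher lipophilicity and lower numbers for lower lipophilicity: compound 1 `CC(=O)NC[C@H]1CN(c2ccc(OC[C@H](O)CNc3ccc(C#N)cc3)c(F)c2)C(=O)O1` gives 1.29; compound 2 `CC(=O)NC[C@H]1CN(c2ccc(OC[C@H](O)CNc3ccccn3)c(F)c2)C(=O)O1` gives 1.6; compound 3 `COc1ccc(N2C[C@H](COc3ccc(N4C[C@H](CNC(C)=O)OC4=O)cc3F)OC2=O)cc1` gives 1.73.

Within the data shown here, compound 2 stands second highest of the three; compound 3 lies within the scatter of it, while compound 1 lies below, the step of a number 0.31 log units higher from compound 1 to compound 2 (beyond the scatter) being the only one-place change measured. Compound 4 `CC(=O)NC[C@H]1CN(c2ccc(OC[C@@H]3CNC(=O)O3)c(F)c2)C(=O)O1` differs from compound 2 by 2-oxo-1,3-oxazolidin-5-yl in place of 1-hydroxy-2-((pyridin-2-yl)amino)ethyl on a saturated chain carbon bound to an oxygen on an aromatic ring. Among the measured compounds shown here, no measured step covers this change: the one step known, a number 0.31 log units higher from compound 1 to compound 2 (beyond the scatter), swaps one aryl group for another on an amine nitrogen and leaves the rest of the chain untouched. Any expectation therefore rests on the groups alone. Given that compound 2 gives 1.6, the step is expected to be a number 1.00 log units lower from compound 2 to compound 4 (beyond the scatter), downward. Compound 4 is estimated at 0.6, in the range 0 to 1.2.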

Compound 4, partition coefficient: 0.01
Estimate against measurement, compound 4: 0.59 log units above; the range from low to high includes it.
By their numbers in this assay, from the lowest: compound 4; then compound 1; then compounds 2 and 3 (each within the scatter of the next).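

In this assay the change on a saturated chain carbon bound to an oxygen on an aromatic ring gives a much larger step than the aryl swap on the amine nitrogen: a number 1.59 log units lower from compound 2 to compound 4 (beyond the scatter) against a number 0.31 log units higher from compound 1 to compound 2 (beyond the scatter) for that swap. The change replaces the whole 1-hydroxy-2-((pyridin-2-yl)amino)ethyl group, aromatic ring included, so the step cannot be divided among its parts. Nothing measured here gives a cause for this step.

Open, going by these compounds, is where a simple primary amine or a carboxylic acid at this place would fall relative to compound 4 and compound 2.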